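A few compounds are considered here, and "the series" means these few. Any claim that something is new, unique, unknown or untested is made for them only; others in the source may bear on it.

In a functional assay on NCI-H322 cells (Homo sapiens) for cytotoxicity, read by MTT assay, with a stated time of 24 h (a higher number here means a weaker inhibitor, a lower number a stronger inhibitor), compound 2 `COc1ccc(/C=C\C(=O)O)c(OCc2cn(-c3ccccc3I)nn2)c1CC=C(C)C` gives 42300 nM.
Compound 3 `COc1ccc(/C=C\C(=O)O)c(OCc2cn(-c3cccnc3Cl)nn2)c1CC=C(C)C` gives 42200 nM in this assay.
Compound 1 `COc1ccc(/C=C\C(=O)O)c(OCc2cn(-c3ccccc3C(=O)N3CCC(O)C3)nn2)c1CC=C(C)C` is recorded as "not determined" (no result reported) in this assay, so it has no reported result there.

Among the compounds with values here, only two numbers are available, and they cannot be told apart: the step of a 1.0-fold lower number from compound 2 to compound 3 (0.00 log units; within the scatter) lies within the scatter, so compound 3 stands level with compound 2. Compound 1 adds nothing; no number was reported for it.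

Compound 4 `COc1ccc(/C=C\C(=O)O)c(OCc2cn(-c3ccccc3C#N)nn2)c1CC=C(C)C` differs from compound 3 by 2-cyanophenyl in place of 2-chloropyridin-3-yl on an aromatic nitrogen. Within the data shown here, the one measured step that bears on this change is the earlier exchange of the aryl group on the same aromatic nitrogen, a 1.0-fold lower number from compound 2 to compound 3 (0.00 log units; within the scatter), which produced no movement at all. On that evidence, swapping one ortho-substituted six-membered aromatic ring for another at this position is expected to leave the number where it is, and no step beyond the scatter is expected for a 1.0-fold lower number from compound 3 to compound 4 (0.00 log units; within the scatter). Compound 4 is therefore estimated at 42000 nM, with a range from 15000 nM to 120000 nM in this assay.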

Compound 4, half-maximal inhibitory concentration: 14400 nM
The estimate for compound 4 lay 2.9-fold (0.46 log units) above the measured number; the whole stated range lies above it.
By their numbers in this assay, from the lowest: compound 4; then compounds 3 and 2 (each within the scatter of the next).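

Within the data shown here, the aryl group on the aromatic nitrogen had so far looked indifferent in this assay, but a 2.9-fold lower number from compound 3 to compound 4 (0.47 log units; beyond the scatter) shows that the number at this position can move, if only modestly. A step of the same printed size, a 2.9-fold lower number from compound 2 to compound 4 (0.47 log units; beyond the scatter), comes from cyano in place of iodo on an aromatic carbon, so the change of that single group on the carbon-only ring is enough to produce the shift. Nothing available accounts for this difference.

The compounds shown leave open how an amine, a carboxylic acid or a longer chain carrying a nitrile would read in place of the cyano group in this assay. They also leave open whether cyano on the chlorine-free pyridine ring would give a similar step.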